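From 3-fluorophenyl to 2,6-dichlorophenyl

A few compounds are considered here, and "the series" means these few. Any claim that something is new, unique, unknown or untested is made for them only; others in the source may bear on it.

In a functional assay on U-87MG ATCC cells for inhibition, with U-87 MG (Homo sapiens) as the target, read by MTT assay, with a stated time of 72 h (a higher number here means a weaker inhibitor, a lower number a stronger inhibitor), compound 3 `Cc1ccnc(NC(c2cccc(F)c2)c2ccc3cccnc3c2O)c1` gives 9200 nM, the second highest of three numbers. Compound 1 `Cc1ccnc(NC(c2ccc(C(F)(F)F)cc2)c2ccc3cccnc3c2O)c1` gives 2100 nM, and compound 2 `Cc1ccnc(NC(c2ccc3cccnc3c2O)c2c(F)cccc2Cl)c1` gives 20600 nM. Compound 4 `Cc1ccnc(NC(c2ccc3cccnc3c2O)c2c(Cl)cccc2Cl)c1` carries 2,6-dichlorophenyl in place of 3-fluorophenyl on the same saturated chain carbon (2,6-dichlorophenyl in place of 3-fluorophenyl on a saturated chain carbon bound to an aromatic carbon and a nitrogen on an aromatic ring). The closest guide is the measured step of a 2.2-fold lower number from compound 2 to compound 3 (0.35 log units; beyond the scatter), which involves 2-chloro-6-fluorophenyl and would point the other way when reversed. The steps of a 9.8-fold higher number from compound 1 to compound 2 (0.99 log units; beyond the scatter) and a 4.4-fold higher number from compound 1 to compound 3 (0.64 log units; beyond the scatter) give wider context. A modest rise in the number is therefore expected, and the estimated step is a 2.1-fold higher number from compound 3 to compound 4 (0.31 log units; beyond the scatter). For compound 4, the estimated value is 19000 nM, within an expected range of 7000 nM to 45000 nM.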

Compound 4, half-maximal inhibitory concentration: 7200 nM
Compound 4: the middle estimate sits 2.6-fold (0.42 log units) above what was measured; measured number inside the range.
By their numbers in this assay, from the lowest: compound 1; then compounds 4 and 3 (each within the scatter of the next); then compound 2.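

In this assay, 2,6-dichlorophenyl and 3-fluorophenyl cannot be told apart on this saturated chain carbon (a 1.3-fold lower number from compound 3 to compound 4 (0.11 log units; within the scatter)). Exchanging a single halogen matters more: chloro in place of fluoro on an aromatic carbon gives a step beyond the scatter (a 2.9-fold lower number from compound 2 to compound 4 (0.46 log units; beyond the scatter)), while 4-(trifluoromethyl)phenyl still gives the lowest number (a 3.4-fold higher number from compound 1 to compound 4 (0.54 log units; beyond the scatter)). Nothing given here accounts for these differences.

The compounds shown leave open how a phenyl ring bearing an amine or a methoxy group would behave on this carbon. They also leave open whether such a group could match compound 1.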